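This account rests on a few compounds, and the source may have more. Where it says the series, first, only, none or still open, it means among the compounds named here.

Measured compounds:
- compound 1, `O=C(Nc1ccc(Oc2ccnc3[nH]ccc23)c(F)c1)c1nn(-c2ccccc2)ccc1=O`, in a functional assay on MCF7 cells (Homo sapiens) for cytotoxicity, read by MTT assay, with a stated time of 72 h (on this read-out lower numbers stand for stronger inhibition and higher numbers for weaker inhibition), gives 34900 nM
- compound 2, `Cc1cc(=O)n(-c2ccc(F)cc2)nc1C(=O)Nc1ccc(Oc2ncnc3[nH]ccc23)cc1`, in this assay gives 4800 nM

Of the two numbers in hand, compound 2 has the lower one; the nearest is compound 1, and the gap between the two values is beyond the usual scatter, so compound 2 counts as the stronger of the pair in this assay. The two compounds differ at more than one place, so no single step can be read from them.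

Compound 3, `Cc1cc(=O)n(-c2ccc(Br)cc2F)nc1C(=O)Nc1ccc(Oc2ncnc3[nH]ccc23)cc1`, is not yet measured. It differs from compound 2 in one place: 4-bromo-2-fluorophenyl in place of 4-fluorophenyl on an aromatic nitrogen. Within the data shown here, nothing in the measured set speaks to this change, since no other compound varies the group on that aromatic nitrogen. The change is therefore expected to produce no step beyond the scatter, with the estimate a 1.2-fold lower number from compound 2 to compound 3 (0.08 log units; within the scatter) from compound 2 to compound 3 in this assay. For compound 3 the expected value in this assay is 4000 nM, within a range of 1500 nM to 12000 nM.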

Compound 3, half-maximal inhibitory concentration: 3210 nM
Compound 3: middle estimate off by 1.2-fold (0.10 log units), on the high side, and the stated range covers the measured number.
By their numbers in this assay, from the lowest: compounds 3 and 2 (each within the scatter of the next); then compound 1.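

The group on the aromatic nitrogen now has its first one-place comparison: in this assay the exchange of 4-fluorophenyl for 4-bromo-2-fluorophenyl gives a 1.5-fold lower number from compound 2 to compound 3 (0.17 log units; within the scatter) and leaves compound 2 and compound 3 indistinguishable on this read-out. This position, on a nitrogen of the six-membered aromatic ring with 2 nitrogen, therefore accepts a bromine and a relocated fluorine on the phenyl ring with no step beyond the scatter, although both compounds still sit in the micromolar range. No measurement in hand bears on why this exchange leaves the value within the scatter.

The exchange alters the phenyl ring at two points at once, so the separate contributions of the bromine and the fluorine stay unresolved, and 4-bromophenyl or 2-fluorophenyl alone would be needed to divide them. From the compounds shown here alone, it also remains open whether this position responds at all to a group of another kind, such as an amine or a carboxylic acid on the phenyl ring, or a longer alkyl chain in place of the ring.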